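A few compounds are considered here, and "the series" means these few. Any claim that something is new, unique, unknown or untested is made for them only; others in the source may bear on it.

Compound 1 `CCC(CC)(c1ccc(OCC(=O)C(C)(C)Cc2ccc3ccccc3c2)c(C)c1)c1ccc(OC[C@@H](O)CO)c(C)c1` reaches only a limit, > 30000 nM, in an assay on HL-60 cells for activation of vitamin D3 receptor (Homo sapiens); a higher number here means that more compound is needed for the effect, a lower number that less compound is needed. Compound 2 `CCC(CC)(c1ccc(OCC(O)C(C)(C)Cc2ccccc2)c(C)c1)c1ccc(OC[C@@H](O)CO)c(C)c1` gives 11000 nM in this assay.

Among the two values shown, compound 2 holds the only real number; the other entry is a limit, (the limit of > 30000 nM in this assay, at which 1 of the 2 values shown sits), and tells nothing more than that. So compound 2 is the only anchor for what follows.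

Compound 3 `CCC(CC)(c1ccc(OCC(O)C(C)(C)CCCc2ccccc2)c(C)c1)c1ccc(OC[C@@H](O)CO)c(C)c1` differs from compound 2 in a single way: phenethyl in place of phenyl on a saturated chain carbon, three bonds along the chain from an oxygen on a saturated carbon. The chain that carries the aromatic ring thus grows longer while everything else in the shared core stays the same. For the measured compounds named here, no measured pair shows what such a lengthening does here, so the direction of the step cannot be read from the data. A modest change in either direction, or none beyond the usual scatter, is the honest expectation; the estimated step from compound 2 to compound 3 is a 1.4-fold higher number from compound 2 to compound 3 (0.13 log units; within the scatter). Compound 3 is therefore expected to give about 15000 nM in this assay, within a range of 4000 nM to 50000 nM.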

Compound 3, half-maximal effective concentration: 3600 nM
Estimate against measurement, compound 3: 4.2-fold (0.62 log units) above; measured number outside the range, below it.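

In this assay putting phenethyl in place of phenyl, on a saturated chain carbon three bonds along the chain from an oxygen on a saturated carbon, gives a 3.1-fold lower number from compound 2 to compound 3 (0.49 log units; beyond the scatter) and so takes the series past a single anchor value. For the compounds shown here, this is the first readable step, and it shows that this position responds to the length of the chain carrying the aromatic ring, with less compound needed for the longer chain. Nothing measured here says why the longer chain has this effect.

From the compounds shown here alone, whether a chain longer than phenethyl lowers the number further or raises it again stays open. So does the effect of an amine or a carboxylic acid at the end of that chain, in place of the aromatic ring, in this assay.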